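Replacing tert-butyl with diethylcarbamoyl in compound 2

This account rests on a few compounds, and the source may have more. Where it says the series, first, only, none or still open, it means among the compounds named here.

compound 1 `CN1C[C@H](C(=O)NC2CC2)[C@@H](c2ccc(/C=C/C(=O)Nc3ccccc3N)cc2)C1`: 10 mL/min/kg
compound 2 `CC(C)(C)N1C[C@H](C(=O)Nc2ccc(Cl)cc2)[C@@H](c2ccc(/C=C/C(=O)Nc3ccccc3N)cc2)C1`: 8 mL/min/kg

Both compounds were tested in an in vitro ADME assay on microsomes from liver (Homo sapiens) for pharmacokinetics, read by LC-MS, with a stated time of 10 min, tested at 1 uM; a higher number here means faster removal of the compound, a lower number slower removal. There, compound 2 gives 8 mL/min/kg, which lies within the usual scatter of compound 1 at 10 mL/min/kg, so the two cannot be told apart. The next compound, compound 3 `CCN(CC)C(=O)N1C[C@H](C(=O)Nc2ccc(Cl)cc2)[C@@H](c2ccc(/C=C/C(=O)Nc3ccccc3N)cc2)C1`, has diethylcarbamoyl in place of tert-butyl on an amine nitrogen in a ring, and it otherwise matches compound 2: diethylcarbamoyl in place of tert-butyl on an amine nitrogen in a ring. For the measured compounds named here, no measured pair shows this change alone, so the data offer no direct precedent. Compound 1 and compound 2 differ in more than one place, yet their numbers remain within the scatter, which argues against expecting a large move. The expected step is a 1.5-fold higher number from compound 2 to compound 3 (0.18 log units; within the scatter), a small upward one within the scatter. For compound 3 the estimated value is 12 mL/min/kg, with an expected range of 6 mL/min/kg to 25 mL/min/kg.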

Compound 3, clearance: 19 mL/min/kg
Compound 3: the middle estimate sits 1.6-fold (0.20 log units) below what was measured; measured number inside the range.
By their numbers in this assay, from the lowest: compounds 2, 1 and 3 (each within the scatter of the next, the first and the last beyond it).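

For the compounds shown here, on the amine nitrogen in the ring, this assay now has its first step in which only one place changes: diethylcarbamoyl in place of tert-butyl gives a 2.4-fold higher number from compound 2 to compound 3 (0.38 log units; beyond the scatter). The earlier pair differed in more than one place and could not show this, whereas here the (4-chlorophenyl)carbamoyl group and the rest of the shared core stay the same, so the modest rise belongs to this one exchange. Nothing in the data gives a reason for the step.

The compounds shown leave open whether the step follows the carbonyl or the two ethyl chains, which an acetyl group or a morpholine-4-carbonyl group on the same nitrogen could help to separate. From the compounds shown here alone, it is also open whether the same exchange gives a similar step when another group replaces the (4-chlorophenyl)carbamoyl group.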